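A few compounds are considered here, and "the series" means these few. Any claim that something is new, unique, unknown or untested is made for them only; others in the source may bear on it.

Among the compounds with values here, compound 2 `COc1ccc(-c2cc(-c3ccccc3)n[nH]2)cc1` stands at the lower of the two numbers measured so far: in a functional assay (Cortical neurone cells, Rattus norvegicus, strain Sprague-Dawley) for cytotoxicity, read by XTT assay, tested at 10 uM, in the presence of a further agent that is not named here (a lower number here means a stronger effect, a higher number a weaker effect of the compound at the concentration tested), compound 2 gives 49.2%, while compound 1 `Cn1nc(-c2ccccc2)cc1-c1ccc2[nH]ccc2c1` gives 63.2%, a gap beyond the usual scatter. Compound 3 `Clc1ccc(-c2cc(-c3ccccc3)n[nH]2)cc1` has not yet been measured; it differs from compound 2 by chloro in place of methoxy on an aromatic carbon. Within the data shown here, no two measured compounds differ in a single place, so nothing shows how such a change moves the read-out in this assay. The expected step from compound 2 to compound 3 is a number 0.8 percentage points higher from compound 2 to compound 3 (within the scatter), none beyond the scatter in either direction. Compound 3 is therefore estimated at 50%, between 35% and 65%.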

Compound 3, a percentage reported as activity, at one concentration (the size of the read-out at that concentration, not a potency): 24.2%
For compound 3 the middle estimate is 25.8 percentage points above the measured one; measured number below the stated range.
By their numbers in this assay, from the lowest: compound 3; then compound 2; then compound 1.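

Replacing methoxy with chloro on this aromatic carbon, para to a large group, gives a number 25 percentage points lower from compound 2 to compound 3 (beyond the scatter) in this assay and so shows that the read-out responds to what sits at this place. Within the data shown here, this is the first comparison here between compounds differing in a single place. Nothing measured here gives a reason for the drop.

One pair cannot show whether chloro itself matters or only the loss of methoxy. The compounds shown also leave open what a plain hydrogen, a methyl or an amine would do at this place.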